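The source may report more compounds than this note shows. Statements on the series, on what has been measured and on what is new or still open speak of the compounds shown alone.

Compound 1 `CCc1ccc(C(=O)Nc2ccc3nc(N4CCN(CC)CC4)cc(C)c3c2)cc1` was examined in a functional assay on MCF7 cells (Homo sapiens) for antiproliferative activity, read by MTT assay, with a stated time of 72 h (a lower number here means a stronger inhibitor, a higher number a weaker inhibitor), where compound 1 gives 3060 nM. Within the data shown here, the only other measured compound, compound 2 `CNc1cc(C)c2cc(NC(=O)c3ccc(Cl)c(Cl)c3)ccc2n1`, gives 2520 nM in this assay; the gap between the two numbers lies within the usual scatter, so compound 1 and compound 2 cannot be told apart on these data, and no step between measured compounds is available to guide the next change.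

Compound 3 `CCN1CCN(c2cc(C)c3cc(NC(=O)c4cc5ccccc5[nH]4)ccc3n2)CC1` has not yet been measured in this assay. Relative to compound 1 the change is 1H-indol-2-yl in place of 4-ethylphenyl on a carbonyl carbon. Among the measured compounds shown here, with no measured step of this kind to draw on, the expected step from compound 1 to compound 3 is a 2.0-fold lower number from compound 1 to compound 3 (0.31 log units; beyond the scatter), a modest shift toward a lower number that may not exceed the scatter. Compound 3 is therefore expected to give about 1500 nM in this assay, within a range from 400 nM to 6000 nM.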

Compound 3, half-maximal inhibitory concentration: 2950 nM
The estimate for compound 3 lay 2.0-fold (0.29 log units) below the measured number; the measured number falls inside the stated range.
By their numbers in this assay, from the lowest: compounds 2, 3 and 1 (each within the scatter of the next).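

Among these compounds, putting 1H-indol-2-yl in place of 4-ethylphenyl on a carbonyl carbon gives a 1.0-fold lower number from compound 1 to compound 3 (0.02 log units; within the scatter) in this assay and provides the only step that can be read at this position. The entering group adds a five-membered aromatic ring and a hydrogen-bond donor, yet compound 3 cannot be told apart from compound 1 on these data. Nothing available explains why the two groups give such similar results.

As far as these compounds go, it remains open whether any group on this carbonyl carbon can move the number beyond the scatter, and a carboxylic acid, a pyridine ring or a simple methyl group would each test that. Compound 2 differs from compound 1 in more than one place, so the effect of the amine on the core also remains unresolved.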